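Swapping a flexible amine chain for a piperidine ring

The compounds below may be only part of what the source reports. "The series", "measured", "known", "first", "only" and "open" are said of these compounds alone.

Two amide-linked compounds built on a shared core have been tested in a functional assay on SK-BR-3 cells (Homo sapiens) for antiproliferative activity, read by MTT assay, with a stated time of 72 h; on this read-out lower numbers stand for stronger inhibition and higher numbers for weaker inhibition. Compound 1, with structure `Cc1cc(NCCN(C)C)nc2ccc(NC(=O)c3ccc(Cl)c(Cl)c3)cc12`, gives 6670 nM in this assay. Compound 2, with structure `CCN1CCN(c2cc(C)c3cc(NC(=O)c4cccc(Br)c4)ccc3n2)CC1`, gives 13300 nM in this assay. Compound 1 stands at the lower of the two numbers, but the gap to compound 2 lies within the usual scatter of repeated measurements, so no real difference between them can be claimed, and the two also differ in more than one place.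

Compound 3, with structure `Cc1cc(N2CCCCC2)nc2ccc(NC(=O)c3ccc(Cl)c(Cl)c3)cc12`, has not yet been measured. It differs from compound 1 in a single way: piperidin-1-yl in place of (2-(dimethylamino)ethyl)amino on an aromatic carbon. A ring with no hydrogen-bond donor thus replaces a chain that carried one. Among the measured compounds shown here, no measured pair shows the effect of such a change on this core, so the expectation rests on compound 1 alone and is held loose. A step of a 1.4-fold higher number from compound 1 to compound 3 (0.15 log units; within the scatter) from compound 1 is expected, slight and toward a higher number, though it may well sit inside the scatter. Compound 3 is therefore estimated to give 9500 nM in this assay, with a range from 3000 nM to 30000 nM.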

Compound 3, half-maximal inhibitory concentration: 42500 nM
Beside the measured number, compound 3's estimate is 4.5-fold (0.65 log units) below it; measured number above the stated range.
By their numbers in this assay, from the lowest: compounds 1 and 2 (each within the scatter of the next); then compound 3.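

In this assay, among the compounds shown here, the first comparison on this core that changes a single place shows that the group on this aromatic carbon, next to the ring nitrogen, matters: piperidin-1-yl in place of (2-(dimethylamino)ethyl)amino gives a 6.4-fold higher number from compound 1 to compound 3 (0.80 log units; beyond the scatter), a modest rise that means weaker inhibition and lies beyond the scatter. The change keeps the count of 6 heavy atoms but replaces an open chain with a ring, so the same number of atoms arranged differently, with 0 hydrogen-bond donors instead of 1 and 1 hydrogen-bond acceptor instead of 2, does not give the same result here. No measurement at hand explains the rise, so the pair records the size of the step but not its cause.

This single step changes the ring, the amine hydrogen and the far dimethylamino nitrogen together, so it leaves open which of these differences accounts for it. A (3-(dimethylamino)propyl)amino chain, a (2-hydroxyethyl)amino chain or a morpholin-4-yl ring at this position on the core of compound 1 would each help to separate these features.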